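The source may hold more compounds than are shown below. What is called first, only, known or untested is meant among the compounds shown, and "the series" means these compounds.

Measured so far in a functional assay on NCI-H460 cells (Homo sapiens) for inhibition, read by MTT assay, with a stated time of 72 h; a higher number here means a weaker inhibitor of growth, a lower number a stronger inhibitor of growth:
- compound 1 `N#C/C(=C\c1c(F)c(F)c(F)c(F)c1F)C(=O)c1c[nH]c2ccccc12`: 35000 nM
- compound 2 `COc1ccc(CNC(=O)/C(C#N)=C/c2ccc[nH]2)cc1`: > 50000 nM, a limit of the assay, not a number

Compound 2 stands at the limit of this assay, its value in this assay being > 50000 nM, as recorded in the limit of > 50000 nM in this assay, at which 1 of the 2 values shown sits. Going by the values given here, compound 1 is built on a different core and gives a measured number, but no single-point step links it to compound 2; the two values show only that one sits at a number and the other at a limit.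

Compound 3 `COc1ccc(CNC(=O)/C(C#N)=C/c2ccc(Br)o2)cc1` is the next compound to be tested: 5-bromofuran-2-yl in place of 1H-pyrrol-2-yl on a double-bonded chain carbon bound to a double-bonded chain carbon. No measured step on this series is available to lean on, and compound 2 is known only as a limit, so no direction can be argued from the numbers shown. The expected size of step in this assay is none beyond the scatter, with a fair chance that a limit is again reported.

Compound 3 is expected to give about 45000 nM in this assay, in the range 15000 nM to 120000 nM. The estimated step for this exchange is an at least 1.1-fold lower number from compound 2 to compound 3 (0.04 log units; that floor lies within the scatter), within the scatter.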

Compound 3, concentration for 50% growth inhibition: 16000 nM
Compound 3: the middle estimate sits 2.8-fold (0.45 log units) above what was measured, and the stated range covers the measured number.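

In this assay, going by these compounds alone, 5-bromofuran-2-yl in place of 1H-pyrrol-2-yl gives an at least 3.1-fold lower number from compound 2 to compound 3 (0.49 log units; beyond the scatter), the first step that can be read beyond the scatter. The place on a double-bonded chain carbon bound to a double-bonded chain carbon therefore responds to the exchange, and the series now has a measured number with the remainder of the structure unchanged. The true size of the step stays open because the value for compound 2 is a limit and not a number: the limit of > 50000 nM in this assay, at which 1 of the 3 values shown sits.

Within the data shown here, the exchange changes several things at once: the ring nitrogen and its hydrogen-bond donor leave, while a ring oxygen and a bromine enter, so the single step cannot assign the gain to either the ring or the bromine. Furan-2-yl without bromine would separate these two parts, 5-chlorofuran-2-yl would test whether another halogen serves at this place, and the core of compound 1 remains without any single-place link to compound 2 or compound 3.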